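Compound 2 to compound 3: methyl to ethyl

The compounds below may be only part of what the source reports. "The series", "measured", "known", "first", "only" and "open" are said of these compounds alone.

In a functional assay on the whole organism with Mus musculus as the target (a higher number here means that more compound is needed for the effect, a lower number that less compound is needed), compound 1 (`O=C1CCC(O)(c2cccc(C(F)(F)F)c2)N1`) gives only a limit, > 200 mg/kg. Within the data shown here, compound 2 (`CN1C(=O)CCC1(O)c1cccc(C(F)(F)F)c1`) gives 51.6 mg/kg, the only actual number so far. Among the measured compounds shown here, the one measured step is an at least 3.8-fold lower number from compound 1 to compound 2 (0.58 log units; beyond the scatter), and it places a methyl on the amide-type nitrogen in the ring. Going by these compounds, its true size remains open, since one end of it is the limit of compound 1.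

Compound 3 (`CCN1C(=O)CCC1(O)c1cccc(C(F)(F)F)c1`) differs from compound 2 by methyl in place of hydrogen on a saturated chain carbon bound to an amide-type nitrogen in a ring. The methyl on the nitrogen thus becomes ethyl, with methyl in place of hydrogen on a saturated chain carbon bound to an amide-type nitrogen in a ring. The step of an at least 3.8-fold lower number from compound 1 to compound 2 (0.58 log units; beyond the scatter) bears on this change only indirectly. It was made on the nitrogen itself and not one carbon further out. A smaller change in this assay therefore seems likely, probably none beyond the scatter. The expected step is a 1.1-fold lower number from compound 2 to compound 3 (0.06 log units; within the scatter). For compound 3 the estimated value is 45 mg/kg, with an expected range from 20 mg/kg to 110 mg/kg.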

Compound 3, dose for half-maximal effect: > 75 mg/kg
Compound 3: a limit, no number; the forecaster's own chance of this, stated with the estimate: 10%; at least 1.6-fold (0.22 log units) between middle value and limit.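

The gain seen when a methyl first went onto the nitrogen does not visibly carry over to the next carbon: methyl in place of hydrogen on a saturated chain carbon bound to an amide-type nitrogen in a ring gives no sign of a lower number in this assay. The change from methyl to ethyl is an at least 1.4-fold higher number from compound 2 to compound 3 (0.16 log units; that floor lies within the scatter), so its printed floor alone does not separate the two compounds beyond the scatter, though the true step may be larger. Compound 3 has no number in this read-out and gives only a limit: the limit of > 75 mg/kg in this assay, at which 1 of the 3 values shown sits.

Going by these compounds, the step that links compound 1 with compound 3 cannot be read, as both of its ends are limits, so the ethyl group cannot be sized against the amide hydrogen, and the true value of compound 3 remains unknown. The compounds shown also leave open how a longer chain such as propyl, or a chain ending in an amine or a carboxylic acid, would fare on this nitrogen in this assay, and so whether methyl is the only substituent there that gives a measurable dose.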